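Ester to Amide at the Carbonyl of a Shared Core

The source may hold more compounds than are shown below. What is called first, only, known or untested is meant among the compounds shown, and "the series" means these compounds.

Compound 1, `COc1ccc2c(c1)OC(c1cc(OC)c(OC)c(OC)c1)C(C(=O)OC(C)C)=C2`: 11800 nM
Compound 2, `COc1ccc2c(c1)OC(c1cc(OC)c(OC)c(OC)c1)C(C(=O)OCCc1ccccc1)=C2`: 16200 nM
Compound 3, `COC(=O)C1=Cc2ccc(OC)cc2OC1c1cc(OC)c(OC)c(OC)c1`: 13800 nM

The three measured compounds share one core and differ only in the group on the oxygen next to the carbonyl. In a functional assay for inhibition of nuclear factor NF-kappa-B complex (Homo sapiens) (on this read-out lower numbers stand for stronger inhibition and higher numbers for weaker inhibition), the steps between them are all small: a 1.4-fold higher number from compound 1 to compound 2 (0.14 log units; within the scatter), a 1.2-fold higher number from compound 1 to compound 3 (0.07 log units; within the scatter) and a 1.2-fold lower number from compound 2 to compound 3 (0.07 log units; within the scatter). Compound 3 stands second highest of the three numbers, with compound 1 nearest and compound 2 furthest, both within the scatter, so no order among the three can be claimed.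

Compound 4, `CNC(=O)C1=Cc2ccc(OC)cc2OC1c1cc(OC)c(OC)c(OC)c1`, is the next step from compound 3. The change is methylamino in place of methoxy on a carbonyl carbon. Among the measured compounds shown here, none of the measured steps bears directly on this change: each of them alters only the chain beyond the ester oxygen and leaves the ester itself in place, and none of them moved the number beyond the scatter. For the measured compounds named here, there is thus no precedent for replacing the oxygen by a nitrogen with a hydrogen-bond donor. With the measured series flat, the expected step for this assay is a 1.0-fold higher number from compound 3 to compound 4 (0.01 log units; within the scatter), with a wide range to reflect the missing precedent. Compound 4 is therefore estimated at 14000 nM, within 5000 nM to 40000 nM.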

Compound 4, half-maximal inhibitory concentration: > 50000 nM
Compound 4: only a limit was reported; the forecaster's own chance of this, stated with the estimate: 10%; at least 3.5-fold (0.55 log units) between middle value and limit.
By their numbers in this assay, from the lowest: compounds 1, 3 and 2 (each within the scatter of the next). At a limit, above all of these: compound 4.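

In this assay compound 4 gives > 50000 nM, which is a limit of the assay and not a number. The change at the carbonyl carbon therefore does what no change in the chain beyond the ester oxygen did, moving the number beyond the scatter: methylamino in place of methoxy gives an at least 3.6-fold higher number from compound 3 to compound 4 (0.55 log units; beyond the scatter), and the two other esters give an at least 3.0-fold higher number from compound 2 to compound 4 (0.48 log units; beyond the scatter) and an at least 4.2-fold higher number from compound 1 to compound 4 (0.62 log units; beyond the scatter). At this position, then, the three esters stay within the scatter of one another whichever group they carry, while the one amide shown reads as weaker than all three.

Going by these compounds, how much weaker compound 4 really is stays open, as these steps give only a floor resting on a single reading: the limit of > 50000 nM in this assay, at which 1 of the 4 values shown sits. Also open, on these data alone, is whether the drop goes with the amide hydrogen or with the amide as such, a question a dimethylamino group on the same carbonyl carbon would address, and whether a carboxylic acid or a longer chain on the amide nitrogen would fare any differently.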